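Amide in Place of Ketone Phenyl: Antiproliferative Outlook

The source may hold more compounds than are shown below. What is called first, only, known or untested is meant among the compounds shown, and "the series" means these compounds.

Compound 1, `COc1cc(-c2nnc(SCC(=O)c3ccccc3)n2N)cc(OC)c1OC`, gives 53000 nM in a functional assay on HCT-116 cells (Homo sapiens) for antiproliferative activity, read by MTT assay, with a stated time of 48 h; a higher number here means a weaker inhibitor, a lower number a stronger inhibitor. Compound 2, `COc1cc(-c2nnc(SCC(=O)Nc3ccccc3C)n2N)cc(OC)c1OC`, reaches only a limit, > 100000 nM, in this assay.

Among the measured compounds shown here, compound 1 thus holds the only definite number; the other value is a limit (the limit of > 100000 nM in this assay, at which 1 of the 2 values shown sits). Compound 3, `COc1cc(-c2nnc(SCC(=O)NCc3ccc(Cl)cc3)n2N)cc(OC)c1OC`, differs from compound 1 by (4-chlorobenzyl)amino in place of phenyl on a carbonyl carbon. For the measured compounds named here, the one step that bears on this, an at least 1.8-fold higher number from compound 1 to compound 2 (0.27 log units; that floor lies within the scatter), also replaced the phenyl on the carbonyl with an amine-linked ring and ran to the limit. A weakening of similar or larger size is therefore expected, a 1.7-fold higher number from compound 1 to compound 3 (0.23 log units; within the scatter). Compound 3 is expected at 90000 nM, between 40000 nM and 200000 nM, with a real chance of only a limit.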

Compound 3, half-maximal inhibitory concentration: > 100000 nM
Compound 3: no number, only a limit; the forecaster's own chance of this, stated with the estimate: 45%; at least 1.1-fold (0.04 log units) between middle value and limit.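

In this assay, compound 3 gives only a limit, so a second amine-linked group on the carbonyl carbon also yields no definite number. Putting (4-chlorobenzyl)amino in place of phenyl on a carbonyl carbon gives an at least 1.8-fold higher number from compound 1 to compound 3 (0.27 log units; that floor lies within the scatter). Compound 2 and compound 3, with different groups on the amide nitrogen, end at the same limit: the limit of > 100000 nM in this assay, at which 2 of the 3 values shown sit.

As far as these compounds go, how far compound 3 truly lies from compound 1 stays open, and the step between compound 2 and compound 3 cannot be read. From the compounds shown here alone, whether a plain amino group or a 4-chlorophenyl group on that carbonyl carbon gives a definite number also stays open.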